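The compounds below may be only part of what the source reports. "The series", "measured", "known", "first", "only" and "open" are said of these compounds alone.

Compound 1 `CC1CC(C(=O)N2CCc3nc(C#Cc4ccccc4)sc3C2)C1` — in an assay on HEK293 cells for positive allosteric modulation of metabotropic glutamate receptor 5 (Homo sapiens), read by FLIPR, with a stated time of 1 h (on this read-out higher numbers stand for an effect only at larger amounts of compound and lower numbers for an effect already at smaller amounts), compound 1 gives 81 nM.
Compound 2 `CC(C)S(=O)(=O)N1CCc2nc(C#Cc3ccccc3)sc2C1` — in this assay compound 2 gives > 10000 nM, which is a limit of the assay and not a number.
Compound 3 `O=S(=O)(C1CC1)N1CCc2nc(C#Cc3ccccc3)sc2C1` — in this assay compound 3 gives > 10000 nM, again a limit of the assay.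

Compound 3 thus stands at the limit, (the limit of > 10000 nM in this assay, at which 2 of the 3 values shown sit), as does compound 2; only compound 1 carries a measured number. The steps of an at least 120-fold higher number from compound 1 to compound 2 (2.09 log units; beyond the scatter) and an at least 120-fold higher number from compound 1 to compound 3 (2.09 log units; beyond the scatter) show that either sulfonyl in place of the (3-methylcyclobutyl)carbonyl moves the value out to the limit. The step that the two limits leave unreadable from compound 2 to compound 3 cannot be read, since both of its ends are limits.

Compound 4 `O=S(=O)(C1CCCCC1)N1CCc2nc(C#Cc3ccccc3)sc2C1` differs from compound 3 by cyclohexyl in place of cyclopropyl on a sulfonyl sulfur. Within the data shown here, the only measured step at this position, from compound 2 to compound 3, is unreadable, and both sulfonyls seen so far sit at the limit. No readable change is therefore expected; compound 4 is expected to stay at the limit, with a step that the limit leaves unreadable from compound 3 to compound 4 as the expected step. The estimate for compound 4 is 15000 nM, with a range from 3000 nM to 60000 nM.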

Compound 4, half-maximal effective concentration: > 10000 nM
Compound 4: a limit, no number; the forecaster's own chance of this, stated with the estimate: 75%; the middle value lies beyond the limit too.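

In this assay compound 4 gives > 10000 nM, a limit and not a number. Its steps from compound 2 and from compound 3 cannot be read. The compounds shown leave open whether the group on the sulfonyl sulfur changes the value at all, and whether any sulfonyl on this core gives a measured number.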